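The source may hold more compounds than are shown below. What is called first, only, known or untested is meant among the compounds shown, and "the series" means these compounds.

Measured compounds:
compound 1 `CCN(c1ccc(C#N)c(Cl)c1)c1cc(-c2ccncc2)ccc1C` — 3580 nM
compound 2 `Cc1noc(C)c1-c1cccc2c1CCCN2c1ccc(C#N)c(C(F)(F)F)c1` — "not determined" (no result reported)

Among the compounds with values here, compound 1 `CCN(c1ccc(C#N)c(Cl)c1)c1cc(-c2ccncc2)ccc1C` is the only compound with a number in a functional assay on PC-3 cells (Homo sapiens) for antiproliferative activity, read by CCK-8 assay, with a stated time of 6 days; a higher number here means a weaker inhibitor, a lower number a stronger inhibitor; compound 2 `Cc1noc(C)c1-c1cccc2c1CCCN2c1ccc(C#N)c(C(F)(F)F)c1` has an entry but no result was reported for it. In this assay compound 1 gives 3580 nM, which therefore stands alone, with no other value to set it against, neither stronger nor weaker on the shown numbers.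

Compound 3 `CCN(c1ccc(C#N)c(Cl)c1)c1cc(-c2cccnc2)ccc1C` has the same atoms as compound 1, joined differently: pyridin-3-yl in place of pyridin-4-yl on an aromatic carbon The shared core of compound 1 is kept, and only the nitrogen of that six-membered aromatic ring moves from one position to another within the ring. Within the data shown here, no step between measured compounds is available to show what such a change does here, so the size of the step from compound 1 to compound 3 in this assay is uncertain. He expects the step of a 1.1-fold higher number from compound 1 to compound 3 (0.05 log units; within the scatter) to be small, in either direction, and not beyond the usual scatter. Compound 3 is therefore expected to give about 4000 nM, with a range from 1500 nM to 10000 nM.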

Compound 3, half-maximal inhibitory concentration: 11000 nM
For compound 3 the middle estimate is 2.8-fold (0.44 log units) below the measured one, and the stated range ends below it.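

In this assay the exchange of pyridin-4-yl for pyridin-3-yl gives a 3.1-fold higher number from compound 1 to compound 3 (0.49 log units; beyond the scatter) and so shows that this position, on an aromatic carbon meta to a large group and para to a methyl group, is sensitive to where the nitrogen sits within the ring. Within the data shown here, the step appears although the two groups have the same count of heavy atoms and the same count of hydrogen-bond acceptors, and the earlier compounds offered no pair that could show such a difference. No measurement is available that accounts for this step, and its origin remains unexplained.

The compounds shown leave open how pyridin-2-yl, or a plain phenyl ring, or a pyridine bearing an amine or a carboxylic acid, would compare with these two groups at the same place. As far as these compounds go, it is also open whether the same difference between the two pyridines would hold with a longer chain in place of the ethyl group on the nitrogen, and compound 2 offers no number to help with either question.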